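The source may report more compounds than this note shows. Statements on the series, on what has been measured and on what is new or still open speak of the compounds shown alone.

Measured compounds:
compound 2 `Cc1ccc(-c2csc(N/N=C/c3cccs3)n2)cc1` — 82.8%
compound 1 `COC(=O)c1cc(-c2csc(N/N=C/c3ccc(Cl)cc3Cl)n2)ccc1OCc1ccccc1` — 63.5%

In a functional assay, read by spectrophotometry, with a stated time of 15 min, tested at 40 ug/mL (a higher number here means a stronger effect of the compound at the concentration tested, a lower number a weaker effect), compound 2 gives 82.8%, the higher of the two numbers. Among the compounds with values here, its nearest neighbour, compound 1, gives 63.5% in this assay, a gap that lies beyond the usual scatter; no single-point step between these two is available, so only their two values can be compared.

Compound 3 `Fc1ccc(-c2csc(N/N=C/c3cccs3)n2)cc1` has not been measured in this assay. It differs from compound 2 in one place: fluoro in place of methyl on an aromatic carbon. Swapping one small group for another of the same size on that aromatic carbon is expected to leave the inhibition close to where compound 2 stands, so the step of a number 5.8 percentage points lower from compound 2 to compound 3 (within the scatter) is expected to stay within the scatter, tilting if anything slightly downward. Compound 3 is therefore estimated at 77% in this assay, within 60% to 92%.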

Compound 3, a percentage reported as inhibition, at one concentration (the size of the read-out at that concentration, not a potency): 87.5%
Estimate against measurement, compound 3: 10.5 percentage points below; the measured number falls inside the stated range.
By their numbers in this assay, from the lowest: compound 1; then compounds 2 and 3 (each within the scatter of the next).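

In this assay, within the data shown here, fluoro in place of methyl on an aromatic carbon, para to a large group, gives a number 4.7 percentage points higher from compound 2 to compound 3 (within the scatter) and so provides the first comparison that differs in one place only. At this position, one group of a single heavy atom can stand in for the other without a difference that rises above the scatter, which the gap between compound 1 and compound 2 could not show, as those two differ in more than one place. Nothing in the available data explains why these two groups read alike.

From the compounds shown here alone, it remains open whether the same aromatic carbon would accept something larger or of another kind, such as trifluoromethyl, methoxy, an amine or a carboxylic acid. Also open, going by these compounds, is which of its several differences from compound 2 goes with the lower number of compound 1.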